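The source may hold more compounds than are shown below. What is called first, only, known or untested is meant among the compounds shown, and "the series" means these compounds.

Two compounds in this series carry numbers in a functional assay for antagonist activity at thromboxane A2 receptor (Rattus norvegicus); a higher number here means weaker binding, a lower number tighter binding. Compound 1 `CC(=O)NCc1ccccc1-c1ccc(COC2CC[C@H](N3CCCCCC3)[C@H]2OC/C=C\CCC(=O)O)cc1` gives 126 nM in this assay, the highest of the two numbers. Compound 2 `O=C(O)CC/C=C\CO[C@@H]1C(OCc2ccc(-c3ccccc3)cc2)CC[C@@H]1N1CCCCC1` gives 15.9 nM in this assay, a lower number beyond the scatter; the two compounds differ in several places at once, so only the two values themselves can be set side by side. Compound 3 `O=C(O)CC/C=C\CO[C@H]1C(OCc2ccc(-c3ccccc3CO)cc2)CC[C@@H]1N1CCCCCC1` has not yet been measured. It differs from compound 1 in one place: hydroxy in place of acetamido on a saturated chain carbon bound to an aromatic carbon. The rest of compound 1 is kept unchanged in compound 3. Among the compounds with values here, no measured pair shows this change, so its size is not known from the data. Compound 2, which carries neither group, gives 15.9 nM in this assay, and the step expected for a 2.1-fold lower number from compound 1 to compound 3 (0.32 log units; beyond the scatter) is a modest move toward a lower number. Compound 3 is expected to give about 60 nM, within a range of 20 nM to 200 nM.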

Compound 3, dissociation constant: 6.31 nM
The estimate for compound 3 lay 9.5-fold (0.98 log units) above the measured number; the whole stated range lies above it.
By their numbers in this assay, from the lowest: compound 3; then compound 2; then compound 1.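

Within this assay, hydroxy in place of acetamido on a saturated chain carbon bound to an aromatic carbon gives a 20-fold lower number from compound 1 to compound 3 (1.30 log units; beyond the scatter) as a large step, so this position is sensitive to what it carries. Acetamido has 4 heavy atoms and hydroxy has 1 heavy atom, while the hydrogen-bond donor and acceptor counts are the same for the two groups, so the step comes with a smaller group and no change in those counts. No measurement at hand explains the step.

Going by these compounds, whether the hydroxy group itself is needed, or only the removal of acetamido, stays open, and a methoxy group, an amine or a bare methyl at this place would separate the two readings. This step rests on a single pair, so its size on other versions of the core is also unknown.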